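This account rests on a few compounds, and the source may have more. Where it says the series, first, only, none or still open, it means among the compounds named here.

Measured compounds:
compound 1 `COc1ccc(C(=O)c2cc(OC)c(OC)c(OC)c2)cc1NC(=O)/C=C/c1ccc(OC)c(OC)c1` — 10200 nM
compound 2 `COc1cc(/C=C/C(=O)Nc2cc(C(=O)c3cc(OC)c(OC)c(OC)c3)ccc2OC)ccc1F` — 12100 nM

Both numbers come from a functional assay on DU-145 cells (Homo sapiens) for cytotoxicity, read by MTT assay, with a stated time of 72 h; on this read-out higher numbers stand for weaker inhibition and lower numbers for stronger inhibition. Compound 1 stands alongside compound 2 there, the two values within the scatter of each other: a 1.2-fold higher number from compound 1 to compound 2 (0.07 log units; within the scatter). Compound 3 `COc1ccc(/C=C/C(=O)Nc2cc(C(=O)c3cc(OC)c(OC)c(OC)c3)cc(OC)c2OC)cc1OC` differs from compound 1 by methoxy in place of hydrogen on an aromatic carbon. Among the measured compounds shown here, no measured step touches this change; the one measured step, fluoro for methoxy, stayed within the scatter, so no size or direction can be read from it. The expected step is a 1.0-fold lower number from compound 1 to compound 3 (0.01 log units; within the scatter), none beyond the scatter. Compound 3 is therefore estimated at 10000 nM, between 4000 nM and 25000 nM.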

Compound 3, half-maximal inhibitory concentration: 7800 nM
The estimate for compound 3 lay 1.3-fold (0.11 log units) above the measured number; the measured number falls inside the stated range.
By their numbers in this assay, from the lowest: compounds 3, 1 and 2 (each within the scatter of the next).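

In this assay, methoxy in place of hydrogen on this aromatic carbon, ortho to a methoxy group and meta to two large groups, gives a 1.3-fold lower number from compound 1 to compound 3 (0.12 log units; within the scatter). The position therefore accepts this added group with no change beyond the scatter, whereas the earlier fluoro step concerned a different place and said nothing about this one. Nothing available bears on what lies behind this result. The compounds shown leave open how an amine, a carboxylic acid or a longer chain such as butoxy would read at this position, and whether any group there moves the number beyond the scatter.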